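A few compounds are considered here, and "the series" means these few. Any claim that something is new, unique, unknown or untested is made for them only; others in the source may bear on it.

Measured compounds:
- compound 1, `Cc1ccc(OCC(=O)NNC(=O)c2cc3ccccc3oc2=O)c(C(=O)c2cccc(Cl)c2)c1`: 68600 nM
- compound 2, `Cc1ccc(OCC(=O)NNC(=O)c2cc3ccccc3oc2=O)c(C(=O)c2ccccc2Br)c1`: 10000 nM
- compound 3, `Cc1ccc(OCC(=O)NNC(=O)c2cc3ccccc3oc2=O)c(C(=O)c2ccccc2)c1`: 89100 nM

All three numbers come from a functional assay on DLA cells (Mus musculus) for cytotoxicity, read by trypan blue exclusion, with a stated time of 48 h; a higher number here means a weaker inhibitor, a lower number a stronger inhibitor. Compound 3 gives the highest number of the three, but its distance to compound 1 is small: a 1.3-fold higher number from compound 1 to compound 3 (0.11 log units; within the scatter). Its distance to compound 2 is larger: an 8.9-fold higher number from compound 2 to compound 3 (0.95 log units; beyond the scatter).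

Compound 4, `Cc1ccc(OCC(=O)NNC(=O)c2cc3ccccc3oc2=O)c(C(=O)c2ccc(Cl)cc2)c1`, has not yet been measured. It differs from compound 3 in one place: chloro in place of hydrogen on an aromatic carbon. The chlorine sits on an aromatic carbon of a six-membered aromatic ring of carbon only, para to a large group; phenyl becomes 4-chlorophenyl.

Among the compounds with values here, two measured steps bear on this. Going from compound 1 to compound 3 removes a chlorine from the same ring and changes little: a 1.3-fold higher number from compound 1 to compound 3 (0.11 log units; within the scatter). Going from compound 2 to compound 3 removes a bromine from that ring and gives a clear change: an 8.9-fold higher number from compound 2 to compound 3 (0.95 log units; beyond the scatter). Within the data shown here, a chlorine at the new place has no direct precedent among the measured compounds, so the closest guide is compound 1, whose halogen on this ring sits elsewhere and made no difference beyond the scatter.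

For compound 4 the expected step is therefore small, if any, and slightly downward: a 1.5-fold lower number from compound 3 to compound 4 (0.17 log units; within the scatter). The estimate for compound 4 in this assay is 60000 nM, within a range from 20000 nM to 180000 nM.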

Compound 4, half-maximal inhibitory concentration: 61600 nM
Compound 4: middle estimate off by 1.0-fold (0.01 log units), on the low side, within the range that was stated.
By their numbers in this assay, from the lowest: compound 2; then compounds 4, 1 and 3 (each within the scatter of the next).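

In this assay, within the data shown here, this is the first reading of a halogen at this place on the ring, para to a large group, and adding the chlorine to the plain phenyl gives a 1.4-fold lower number from compound 3 to compound 4 (0.16 log units; within the scatter). Shifting the chlorine from 3-chlorophenyl to 4-chlorophenyl gives a 1.1-fold lower number from compound 1 to compound 4 (0.05 log units; within the scatter), so neither chlorine placement shown stands apart from the plain phenyl, whereas the 2-bromophenyl ring of compound 2 does stand apart, with a 6.2-fold higher number from compound 2 to compound 4 (0.79 log units; beyond the scatter). Nothing available here gives a reason for this pattern.

Compound 2 differs from the chlorine compounds in both the halogen and its place on the ring, so the compounds shown cannot tell whether the bromine itself or its place goes with the lower number; a 2-chlorophenyl or a 4-bromophenyl ring would separate the two. Also open, going by these compounds, is whether a group of a different kind at this same place, such as an amine, a carboxylic acid or a methoxy group, would move the number beyond the scatter, as chlorine here does not.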